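A few compounds are considered here, and "the series" means these few. Any claim that something is new, unique, unknown or untested is made for them only; others in the source may bear on it.

Compound 1, `Nc1ccccc1NC(=O)c1ccc(Cn2cc(-c3ccc(NC(=O)NCc4cccnc4)cc3)nn2)cc1`, gives 8100 nM in a functional assay on HepG2 cells (Homo sapiens) for cytotoxicity, read by MTT assay, with a stated time of 72 h; a higher number here means a weaker inhibitor, a lower number a stronger inhibitor.
Compound 2, `Nc1ccccc1NC(=O)c1ccc(NC(=S)NCc2cncc(F)c2)cc1`, gives 13000 nM in this assay.
Compound 3, `Nc1ccc(CNC(=O)Nc2ccc(C(=O)Nc3ccccc3N)cc2)cn1`, gives 3100 nM in this assay.

All three share a core built around a benzamide that carries an amino-substituted aniline, and they differ in the group attached to the far side of that core. Among these three numbers, compound 2 has the highest; its gap to compound 1 lies within the scatter of this kind of measurement, so the two cannot be told apart, while its gap to compound 3 lies beyond the scatter.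

Compound 4, `Nc1ccccc1NC(=O)c1ccc(NC(=S)NCc2ccc(Cl)nc2)cc1`, is not yet measured. It differs from compound 2 in one place: 6-chloropyridin-3-yl in place of 5-fluoropyridin-3-yl on a saturated chain carbon bound to an amide-type nitrogen. Both groups are a six-membered aromatic ring with one nitrogen and a single halogen, so the change swaps one halogen for another and moves it to a different point on the ring. Within the data shown here, no measured pair in this set shows what such a swap does in this assay, so there is no step to lean on. The expectation is a step no larger than the scatter, a 1.1-fold lower number from compound 2 to compound 4 (0.03 log units; within the scatter), in no firm direction. Compound 4 is therefore estimated at 12000 nM, with a likely range from 5000 nM to 30000 nM.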

Compound 4, half-maximal inhibitory concentration: 19000 nM
Beside the measured number, compound 4's estimate is 1.6-fold (0.20 log units) below it, within the range that was stated.
By their numbers in this assay, from the lowest: compound 3; then compounds 1, 2 and 4 (each within the scatter of the next, the first and the last beyond it).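

Among these compounds, this pair is the first in the set to differ in one place, and in this assay it gives a 1.5-fold higher number from compound 2 to compound 4 (0.16 log units; within the scatter). On a saturated chain carbon bound to an amide-type nitrogen, 6-chloropyridin-3-yl and 5-fluoropyridin-3-yl therefore cannot be told apart: exchanging one halogen for another and placing it at a different point on the ring leaves no readable mark on the number. Nothing measured here speaks to the reason for this result.

The pair changes the halogen and its place on the ring together, so the two changes cannot be separated. Going by these compounds, it also remains open how the number would respond to a pyridin-3-yl with no halogen, a ring bearing a carboxylic acid, or a longer chain carrying the ring.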